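The source may report more compounds than this note shows. Statements on the series, on what has been measured and on what is new or still open speak of the compounds shown alone.

Three compounds share one core and differ only in the group on a carbonyl carbon. In a physicochemical assay for solubility, read by HPLC, in phosphate buffer, measured as kinetic solubility, at pH 7.4 (on this read-out higher numbers stand for higher solubility and lower numbers for lower solubility), compound 1 `NS(=O)(=O)c1ccc(-c2cc(C(=O)C3CC3)nn2-c2ccc(Cl)cc2)cc1`, carrying cyclopropyl, gives 25600 nM. Compound 2 `NS(=O)(=O)c1ccc(-c2cc(C(=O)C3CCCC3)nn2-c2ccc(Cl)cc2)cc1`, carrying cyclopentyl, gives 4600 nM, and compound 3 `NS(=O)(=O)c1ccc(-c2cc(C(=O)CC3CCCC3)nn2-c2ccc(Cl)cc2)cc1`, carrying cyclopentylmethyl, gives 2600 nM. Compound 3 therefore stands level with compound 2 within the scatter, and well apart from compound 1.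

The measured steps are a 5.6-fold lower number from compound 1 to compound 2 (0.75 log units; beyond the scatter) and a 9.8-fold lower number from compound 1 to compound 3 (0.99 log units; beyond the scatter), both modest, while a 1.8-fold lower number from compound 2 to compound 3 (0.25 log units; within the scatter) does not stand out from the scatter.

Compound 4 `NS(=O)(=O)c1ccc(-c2cc(C(=O)N3CC4CC4C3)nn2-c2ccc(Cl)cc2)cc1` has not yet been measured. The change that leads to it is a group of 6 heavy atoms (5 carbon, 1 nitrogen; one three-membered non-aromatic ring of carbon only, one five-membered non-aromatic ring with 1 hetero atom) in place of a group of 6 heavy atoms (6 carbon; one five-membered non-aromatic ring of carbon only), on a carbonyl carbon. Going by the values given here, all three measured groups contain carbon only, so no measured step shows what a ring nitrogen on this carbonyl carbon does. Those steps can only suggest a likely size, which is modest. The direction rests on thin evidence: a rise is expected, since the entering group holds a three-membered ring, as does the cyclopropyl of compound 1 at 25600 nM.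

The estimated change is a 3.1-fold higher number from compound 3 to compound 4 (0.49 log units; beyond the scatter). For compound 4 the expected value is 8000 nM, with an estimated range of 2500 nM to 25000 nM.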

Compound 4, solubility: 36600 nM
Compound 4: the middle estimate sits 4.6-fold (0.66 log units) below what was measured, outside the stated range (above it).
By their numbers in this assay, from the lowest: compounds 3 and 2 (each within the scatter of the next); then compounds 1 and 4 (each within the scatter of the next).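

Until now, the two larger carbon-only groups, cyclopentyl and cyclopentylmethyl, had both given numbers well under that of cyclopropyl, which made it look as if bigger groups on this carbonyl carbon go with lower numbers in this assay. Compound 4 goes against that picture: its group has the same 6 heavy atoms as cyclopentylmethyl, yet the result is a 14-fold higher number from compound 3 to compound 4 (1.15 log units; beyond the scatter), along with an 8.0-fold higher number from compound 2 to compound 4 (0.90 log units; beyond the scatter), so heavy-atom count alone does not set the number at this position. The remaining step is a 1.4-fold higher number from compound 1 to compound 4 (0.16 log units; within the scatter), which places a group of 6 heavy atoms level with the much smaller cyclopropyl, and nothing available explains why this happens.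

The entering group brings a ring nitrogen and a three-membered ring together, so the compounds shown cannot say which of the two goes with the higher number. A plain pyrrolidine on this carbonyl carbon would have the ring nitrogen without the three-membered ring, and an all-carbon group with the same two rings would have the reverse, so each would separate the two features.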